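The source may report more compounds than this note shows. Statements on the series, on what has been measured and on what is new or still open speak of the compounds shown alone.

Measured compounds in an ADME assay on Huh7.5.1 cells (Homo sapiens) for cytotoxicity, read by ATP content, with a stated time of 48 h; on this read-out lower numbers stand for higher toxicity in this test and higher numbers for lower toxicity in this test:
- compound 1 `Cc1oc(-c2ccc(F)cc2)nc1CN1CCC(C(=O)NCCCN2C[C@H](C)C[C@H](C)C2)CC1` — 12800 nM
- compound 2 `Cc1ccccc1-c1nc(CN2CCC(C(=O)NCCCN3CCCCC3)CC2)c(C)o1` — 18100 nM
- compound 3 `Cc1ccccc1-c1nc(CN2CCC(C(=O)N3CCN(CCN(C)C)CC3)CC2)c(C)o1` — 27200 nM

Compound 1 holds the lowest of the three numbers in this assay; compound 2 lies within the scatter of it, compound 3 beyond it. Going by the values given here, the one step between measured compounds that differ in a single place is a 1.5-fold higher number from compound 2 to compound 3 (0.18 log units; within the scatter), a change on the carbonyl carbon of the shared core.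

Compound 4 `COc1cccc(OC)c1-c1nc(CN2CCC(C(=O)NCCCN3C[C@H](C)C[C@H](C)C3)CC2)c(C)o1` differs from compound 1 by 2,6-dimethoxyphenyl in place of 4-fluorophenyl on an aromatic carbon. Among the compounds with values here, no measured step touches that aromatic carbon, so nothing in the set bears on this change. Going from compound 1 to compound 4 the number in this assay is therefore expected to stay within the scatter, as a 1.0-fold higher number from compound 1 to compound 4 (0.01 log units; within the scatter). Compound 4 is estimated at 13000 nM, in the range 5000 nM to 35000 nM.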

Compound 4, half-maximal cytotoxic concentration: 77100 nM
The estimate for compound 4 lay 5.9-fold (0.77 log units) below the measured number; measured number above the stated range.
By their numbers in this assay, from the lowest: compounds 1, 2 and 3 (each within the scatter of the next, the first and the last beyond it); then compound 4.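

The aromatic carbon of the shared core, untouched by any earlier step, is a place where one change moves the number in this assay: 2,6-dimethoxyphenyl in place of 4-fluorophenyl gives a 6.0-fold higher number from compound 1 to compound 4 (0.78 log units; beyond the scatter). Going by these compounds alone, this step lies beyond the scatter, whereas the one earlier step, on the carbonyl carbon, lies within it. Nothing available explains the shift.

Open, on these data alone, is whether an unsubstituted phenyl or a phenyl with a single methoxy group on this carbon would stand nearer compound 1 or compound 4. Also open, as far as these compounds go, is whether 2,6-dimethoxyphenyl gives a similar step with the carbonyl substituent of compound 3.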